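A few compounds are considered here, and "the series" means these few. Any claim that something is new, unique, unknown or untested is made for them only; others in the source may bear on it.

Of the compounds shown here, three share one core and have been measured in an assay on microsomes from brain for inhibition of Fatty-acid amide hydrolase 1 (Rattus norvegicus), read by fluorescence and HPLC, with a stated time of 60 min; on this read-out higher numbers stand for weaker inhibition and lower numbers for stronger inhibition. Compound 1 `CCCCCCCCc1ccc(OCC(=O)Cn2nnc(-c3cccs3)n2)cc1` gives 32 nM. Compound 2 `CCCCCCCCc1ccc(OCC(=O)Cn2nnc(Cc3ccccc3)n2)cc1` gives 66 nM. Among the measured compounds shown here, the one measured step, a 2.1-fold higher number from compound 1 to compound 2 (0.31 log units; beyond the scatter), is the only change in this set that has been put to the test. Compound 3 `CCCCCCCCc1ccc(OCC(=O)Cn2nnnc2-c2ccncc2)cc1` gives 190 nM, the highest of the three numbers; its distance from compound 2 and from compound 1 lies beyond the scatter, so on these numbers compound 3 is the weakest inhibitor of the three.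

Compound 4 `CCCCCCCCc1ccc(OCC(=O)Cn2nnnc2-c2cccc(C(=O)O)c2)cc1` differs from compound 3 in one place: 3-carboxyphenyl in place of pyridin-4-yl on an aromatic carbon. The step from compound 1 to compound 2 concerns a different position on the core and a different pair of groups, so it does not bear directly on this change; it only shows that a swap of the aromatic substituent can move the number by a modest amount. Nothing in the set tests an exchange of a pyridin-4-yl for a 3-carboxyphenyl. Given this, compound 4 is expected to stay in the neighbourhood of compound 3, with a step of a 1.6-fold higher number from compound 3 to compound 4 (0.20 log units; within the scatter) that may well lie within the scatter, and a somewhat higher number is thought slightly more likely than a lower one. The estimate for compound 4 in this assay is 300 nM, with a range from 80 nM to 1500 nM.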

Compound 4, half-maximal inhibitory concentration: 1800 nM
The estimate for compound 4 lay 6.0-fold (0.78 log units) below the measured number; measured number above the stated range.
By their numbers in this assay, from the lowest: compound 1; then compound 2; then compound 3; then compound 4.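

In this assay, placing 3-carboxyphenyl instead of pyridin-4-yl on the aromatic carbon between two ring nitrogen atoms gives a 9.5-fold higher number from compound 3 to compound 4 (0.98 log units; beyond the scatter), a step beyond the scatter. This shows that the number responds clearly to the group at this place and that a six-membered aromatic ring there does not by itself preserve the inhibition seen with compound 3. The earlier measured step concerned a different pair of groups and did not test this exchange, while this one replaces a ring with one hetero atom by a carbon-only ring that carries a carboxylic acid.

No measurement shown gives a reason for this step. On these data alone, it remains open whether the higher number goes with the carboxylic acid itself or with the change of ring, a question that a plain phenyl group or the methyl ester of the acid at this place would help to separate.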